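Moving a chlorine around a urea-linked phenyl ring

The source may hold more compounds than are shown below. What is called first, only, known or untested is meant among the compounds shown, and "the series" means these compounds.

Measured compounds in a functional assay on NCI-H460 cells (Homo sapiens) for cytotoxicity, read by MTT assay, with a stated time of 72 h; on this read-out higher numbers stand for weaker inhibition and lower numbers for stronger inhibition:
- compound 1, `CN(C)CCCNc1nc(-c2ccc(NC(=O)Nc3ccc(Cl)cc3)cc2)nc2c(Cl)c(Cl)sc12`, gives 230 nM
- compound 2, `CN(C)CCCNc1nc(-c2ccc(NC(=O)Nc3ccccc3Cl)cc2)nc2c(Cl)c(Cl)sc12`, gives 490 nM
- compound 3, `CN(C)CCNc1nc(-c2ccc(NC(=O)Nc3ccc(Cl)cc3)cc2)nc2ccsc12`, gives 130 nM

Compounds 1 and 2 share one core and differ only at the far end of the urea: 2-chlorophenyl in place of 4-chlorophenyl on an amide-type nitrogen. That change gave a 2.1-fold higher number from compound 1 to compound 2 (0.33 log units; beyond the scatter), a modest loss of potency that still lies beyond the usual scatter of this assay.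

Compound 3 carries a different core, and the difference between the core of compound 1 and the core of compound 3 is not broken down here. Its value sits within the scatter of compound 1, so the two cannot be ranked against each other, while compound 2 gives a clearly higher number than compound 3.

Compound 4, `CN(C)CCNc1nc(-c2ccc(NC(=O)Nc3ccccc3Cl)cc2)nc2ccsc12`, has not yet been measured. It relates to compound 3 exactly as compound 2 relates to compound 1: 2-chlorophenyl in place of 4-chlorophenyl on an amide-type nitrogen. The place of the change is the same in both pairs, so this is the same change made on a second core.

If the change behaves on the core of compound 3 as it did on the core of compound 1, the step is expected to be about a 2.1-fold higher number from compound 3 to compound 4 (0.32 log units; beyond the scatter), because the measured precedent is a 2.1-fold higher number from compound 1 to compound 2 (0.33 log units; beyond the scatter). On that basis compound 4 is expected to give 270 nM in this assay, with a plausible range from 130 nM to 560 nM. Among the measured compounds shown here, only one measured pair supports this, so the expectation rests on thin ground.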

Compound 4, half-maximal inhibitory concentration: 230 nM
Beside the measured number, compound 4's estimate is 1.2-fold (0.07 log units) above it; low and high end bracket the measured number.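

In this assay, placing 2-chlorophenyl instead of 4-chlorophenyl on the amide-type nitrogen of the second core gives a 1.8-fold higher number from compound 3 to compound 4 (0.25 log units; within the scatter), so this step alone does not separate the two compounds. Set side by side, the steps on the two cores do not differ by more than repeated measurements of this kind would be expected to: the same change on two cores in this assay, a 2.1-fold higher number (0.33 log units; beyond the scatter) from compound 1 to compound 2 and a 1.8-fold higher number (0.25 log units; within the scatter) from compound 3 to compound 4, 1.2-fold (0.08 log units) apart, within the scatter of two such steps. Among the compounds shown here, this is consistent with the change carrying over from one core to the other, but it rests on just two pairs, and since only the step on the first core lies beyond the scatter, it does not show a real effect of the change on the core of compound 3, or predict the result on any further core.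

The compounds shown leave open whether the result depends on chlorine itself, as a comparison of 2-bromophenyl with 4-bromophenyl or of either chlorophenyl group with plain phenyl could test. They also leave open whether the same pattern would hold if a morpholine replaced the dimethylamino group at the end of the side chain.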